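Hydrazone replacements on a shared triazolopyrimidine-free core

The source may report more compounds than this note shows. Statements on the series, on what has been measured and on what is new or still open speak of the compounds shown alone.

Measured so far in a functional assay on ECa-109 cells (Homo sapiens) for antiproliferative activity, read by MTT assay, with a stated time of 72 h; on this read-out higher numbers stand for weaker inhibition and lower numbers for stronger inhibition:
- compound 1 `CCCSc1nc(N/N=C/c2ccccc2Cl)c2nnn(Cc3ccccc3)c2n1`: 6180 nM
- compound 2 `CCCSc1nc(N/N=C/c2c(O)ccc3ccccc23)c2nnn(Cc3ccccc3)c2n1`: 9290 nM

Compound 1 holds the lowest of the two numbers; the nearest is compound 2, a 1.5-fold higher number from compound 1 to compound 2 (0.18 log units; within the scatter).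

Compound 3 `CCCSc1nc(N/N=C(\C)c2ccc(Br)cc2)c2nnn(Cc3ccccc3)c2n1` differs from compound 1 as follows: a group of 10 heavy atoms (8 carbon, 1 nitrogen, 1 bromine; one six-membered aromatic ring of carbon only) in place of a group of 9 heavy atoms (7 carbon, 1 nitrogen, 1 chlorine; one six-membered aromatic ring of carbon only), on a nitrogen on an aromatic ring. Among the measured compounds shown here, no measured step touches this change; the only step, from compound 1 to compound 2, swaps the aromatic group on the carbon with a double bond to nitrogen and stays within the scatter. The step of a 1.1-fold higher number from compound 1 to compound 3 (0.02 log units; within the scatter) in this assay is therefore expected to be none beyond the scatter. Compound 3 is estimated at 6500 nM, with a range from 2500 nM to 17000 nM.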

Compound 3, half-maximal inhibitory concentration: 4670 nM
The estimate for compound 3 lay 1.4-fold (0.14 log units) above the measured number; the range from low to high includes it.
By their numbers in this assay, from the lowest: compounds 3, 1 and 2 (each within the scatter of the next).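

In this assay, a group of 10 heavy atoms with 1 bromine in place of a group of 9 heavy atoms with 1 chlorine, on a nitrogen on an aromatic ring, gives a step within the scatter (a 1.3-fold lower number from compound 1 to compound 3 (0.12 log units; within the scatter)). This position therefore accepts this exchange with no step beyond the scatter, which the earlier step, a change on a carbon with a double bond to nitrogen, could not show. No evidence bears on this result.

Open, from the compounds shown here alone, is whether an amine or a carboxylic acid in this group would give a step beyond the scatter. Also open, going by these compounds, is how a longer chain on the carbon with a double bond to nitrogen would read.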